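A Two-Nitrogen Ring at the Triple Bond of Compound 1

The source may report more compounds than this note shows. Statements on the series, on what has been measured and on what is new or still open speak of the compounds shown alone.

Three compounds have been measured in an assay on Sf9 cells for inhibition of mitogen-activated protein kinase kinase kinase 14 variant S549D (Homo sapiens), with a stated time of 30 min, in the presence of a further agent that is not named here; on this read-out higher numbers stand for weaker inhibition and lower numbers for stronger inhibition:

Compound 1 `C=Cc1cc(C#Cc2ccc3ncn(-c4ccnc(N)n4)c3c2)ccn1` gives 20000 nM
Compound 2 `C#Cc1cc(C#Cc2ccc3ncn(-c4ccnc(N)n4)c3c2)ccn1` gives 31600 nM
Compound 3 `C=Cc1ccnc(C#Cc2ccc3ncn(-c4ccnc(N)n4)c3c2)n1` gives 1580 nM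

Compound 1 stands second highest of the three numbers. Its nearest neighbour is compound 2, reached by a 1.6-fold higher number from compound 1 to compound 2 (0.20 log units; within the scatter). Its furthest is compound 3, reached by a 13-fold lower number from compound 1 to compound 3 (1.10 log units; beyond the scatter).

Compound 4 `C#Cc1cnc(C#Cc2ccc3ncn(-c4ccnc(N)n4)c3c2)nc1` is the next compound. Compared with compound 1, the change is a group of 8 heavy atoms (6 carbon, 2 nitrogen; one six-membered aromatic ring with 2 hetero atoms) in place of a group of 8 heavy atoms (7 carbon, 1 nitrogen; one six-membered aromatic ring with 1 hetero atom), on a triple-bonded carbon. Going by the values given here, two measured steps bear on this. The step of a 13-fold lower number from compound 1 to compound 3 (1.10 log units; beyond the scatter) shows the same kind of exchange, a ring with one hetero atom giving way to a ring with two, and it was large. The step of a 1.6-fold higher number from compound 1 to compound 2 (0.20 log units; within the scatter) shows the exchange of a double bond outside the ring for a triple bond, and it stayed within the scatter. Together they suggest a large downward step, estimated as a 10-fold lower number from compound 1 to compound 4 (1.00 log units; beyond the scatter). Compound 4 is therefore expected to give about 2000 nM, with a range from 700 nM to 6000 nM.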

Compound 4, half-maximal inhibitory concentration: 25100 nM
Estimate against measurement, compound 4: 13-fold (1.10 log units) below, outside the stated range (above it).
By their numbers in this assay, from the lowest: compound 3; then compounds 1, 4 and 2 (each within the scatter of the next).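

At this triple-bonded carbon, a ring with two hetero atoms does not by itself lower the number: the steps of a 1.3-fold higher number from compound 1 to compound 4 (0.10 log units; within the scatter) and a 1.3-fold lower number from compound 2 to compound 4 (0.10 log units; within the scatter) show no change from either ring with one hetero atom. The two rings with two hetero atoms also separate clearly, with a 16-fold higher number from compound 3 to compound 4 (1.20 log units; beyond the scatter), so the low number of compound 3 cannot be credited to the count of hetero atoms alone. Nothing measured here explains the difference between these two rings.

The compounds shown leave open whether the low number of compound 3 goes with its double bond outside the ring or with other features of that ring, as the two rings differ in more than that bond. Also open, from the compounds shown here alone, is how a ring of this kind would behave carrying an amine or a longer chain in place of the vinyl or ethynyl group.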